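Replacing 4-fluoro-3-methylphenyl with 3,4-dihydroxyphenyl in compound 2

The compounds below may be only part of what the source reports. "The series", "measured", "known", "first", "only" and "open" are said of these compounds alone.

In a functional assay on U-251 cells (Homo sapiens) for cytotoxicity (on this read-out higher numbers stand for weaker inhibition of growth and lower numbers for stronger inhibition of growth), compound 1 `COc1ccc(C2=C(c3ccc(SC)cc3)CC3CCCN3C2=O)cc1Br` gives 800 nM while compound 2 `CSc1ccc(C2=C(c3ccc(F)c(C)c3)C(=O)N3CCCC3C2)cc1` gives 200 nM as the lower of the two numbers. Compound 3 `CSc1ccc(C2=C(c3ccc(O)c(O)c3)C(=O)N3CCCC3C2)cc1` is still unmeasured and carries 3,4-dihydroxyphenyl in place of 4-fluoro-3-methylphenyl on a double-bonded ring carbon at the same place in the shared core. Among the measured compounds shown here, only one measured step bears on this place: a 4.0-fold lower number from compound 1 to compound 2 (0.60 log units; beyond the scatter) when 4-fluoro-3-methylphenyl replaced 3-bromo-4-methoxyphenyl, a modest step beyond the scatter. For the measured compounds named here, no measured compound carries hydroxy groups, so the direction remains uncertain. A modest rise toward weaker inhibition of growth is nevertheless expected in this assay and the estimated change is a 3.0-fold higher number from compound 2 to compound 3 (0.48 log units; beyond the scatter) on this basis. Compound 3 is expected at 600 nM with an estimated range from 150 nM to 2500 nM in this assay.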

Compound 3, concentration for 50% growth inhibition: 30000 nM
Beside the measured number, compound 3's estimate is 50-fold (1.70 log units) below it, outside the stated range (above it).
By their numbers in this assay, from the lowest: compound 2; then compound 1; then compound 3.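

In this assay, the place on the double-bonded ring carbon proves far more sensitive to the choice of aryl group than the earlier pair showed: a 4.0-fold lower number from compound 1 to compound 2 (0.60 log units; beyond the scatter) was only a modest step, whereas putting in 3,4-dihydroxyphenyl gives a 150-fold higher number from compound 2 to compound 3 (2.18 log units; beyond the scatter) and marks a large loss of growth inhibition. The loss is not confined to one comparison, as the same group in place of 3-bromo-4-methoxyphenyl gives a 38-fold higher number from compound 1 to compound 3 (1.57 log units; beyond the scatter) and is thus well behind both other aryl groups shown. No measurement at hand accounts for the size of this loss.

The compounds shown leave open whether a single hydroxy group on this phenyl ring would bring the same loss, or whether both are needed. They also leave open how a methoxy group, an amine or a carboxylic acid would fare at this place on the ring.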